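The source may report more compounds than this note shows. Statements on the series, on what has been measured and on what is new or still open speak of the compounds shown alone.

Of the compounds shown here, three built on a shared core have been measured in a functional assay (Cavia porcellus) with sulfonylurea receptors; K-ATP channels (Homo sapiens) as the target; on this read-out higher numbers stand for weaker inhibition and lower numbers for stronger inhibition. Compound 1 `CC(O)(C(=O)Nc1ccc(S(=O)(=O)c2ccccc2)c(O)c1)C(F)(F)F` gives 430 nM in this assay. Compound 2 `COc1cc(NC(=O)C(C)(O)C(F)(F)F)ccc1S(=O)(=O)c1ccccc1` gives 5900 nM, and compound 3 `Cc1cc(NC(=O)C(C)(O)C(F)(F)F)ccc1S(=O)(=O)c1ccccc1` gives 1600 nM. Compound 3 thus stands second highest of the three numbers: it is reached by a 3.7-fold higher number from compound 1 to compound 3 (0.57 log units; beyond the scatter) and by a 3.7-fold lower number from compound 2 to compound 3 (0.57 log units; beyond the scatter), while the remaining pair shows a 14-fold higher number from compound 1 to compound 2 (1.14 log units; beyond the scatter). Compound 4 `CC(O)(C(=O)Nc1ccc(S(=O)(=O)c2ccccc2)c([N+](=O)[O-])c1)C(F)(F)F` has not yet been measured; it differs from compound 3 by nitro in place of methyl on an aromatic carbon. Among the measured compounds shown here, no measured step swaps methyl for nitro at this place, so the steps that lead to compound 3 are the only guide. The steps of a 3.7-fold higher number from compound 1 to compound 3 (0.57 log units; beyond the scatter) and a 3.7-fold lower number from compound 2 to compound 3 (0.57 log units; beyond the scatter) show that exchanging one small group for another at this place moves the number by a modest amount in either direction, whereas a 14-fold higher number from compound 1 to compound 2 (1.14 log units; beyond the scatter) shows that a larger swing is possible. The change to compound 4 is therefore expected to give a modest step, a 1.6-fold higher number from compound 3 to compound 4 (0.19 log units; within the scatter), with the direction uncertain and a somewhat higher number thought more likely. In this assay compound 4 is estimated at 2500 nM, within a range from 700 nM to 9000 nM.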

Compound 4, half-maximal inhibitory concentration: > 30000 nM
Compound 4 gave a limit, no number; the forecaster's own chance of this, stated with the estimate: 3%; middle value at least 12-fold (1.07 log units) from the limit.
By their numbers in this assay, from the lowest: compound 1; then compound 3; then compound 2. At a limit, above all of these: compound 4.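

In this assay, compound 4 gives a limit of the assay and not a number: the limit of > 30000 nM in this assay, at which 1 of the 4 values shown sits. Even read as limits, the steps are clear: an at least 18-fold higher number from compound 3 to compound 4 (1.27 log units; beyond the scatter), an at least 5.0-fold higher number from compound 2 to compound 4 (0.70 log units; beyond the scatter) and an at least 69-fold higher number from compound 1 to compound 4 (1.84 log units; beyond the scatter), so nitro on this aromatic carbon, ortho to a group of 9 heavy atoms, stands apart from methoxy, methyl and hydroxy at the same place. The earlier compounds shown here showed only moves among readable numbers, and this change shows that a single group here can carry the read-out beyond all of them, so the position is far less forgiving than those three groups suggested.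

How far the number of compound 4 lies past the limit stays unknown, and nothing shown tells whether the larger size of nitro, its hydrogen-bond acceptors or some other feature lies behind the step. On these data alone, it also remains open whether an amine, a nitrile or a carboxylic acid at this place would stay in the range of hydroxy, methyl and methoxy or would follow nitro past the limit.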